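Cytotoxicity limits in the series, from compound 3 to compound 4

The compounds below may be only part of what the source reports. "The series", "measured", "known", "first", "only" and "open" are said of these compounds alone.

Measured in an ADME assay on MT4 cells (Homo sapiens) for cytotoxicity, read by XTT assay, with a stated time of 5 days; on this read-out higher numbers stand for lower toxicity in this test and lower numbers for higher toxicity in this test:
- compound 1 `CNC(=O)[C@@H](NC(=O)[C@](O)(CCCN(Cc1ccc(Br)cc1)NC(=O)[C@@H](NC(=O)OC)C(C)(C)C)Cc1ccccc1)C(C)(C)C`: > 10000 nM
- compound 2 `CNC(=O)[C@H](CC(C)C)NC(=O)[C@@](O)(CCCN(Cc1ccc(Br)cc1)NC(=O)[C@@H](NC(=O)OC)C(C)(C)C)Cc1ccccc1`: > 10000 nM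
- compound 3 `CNC(=O)[C@@H](NC(=O)[C@@](O)(CCCN(Cc1ccc(-c2ccncc2)cc1)NC(=O)[C@@H](NC(=O)OC)C(C)(C)C)Cc1ccccc1)C(C)(C)C`: > 50000 nM

All three entries are limits of the assay, not numbers. Compound 3 stands only at the limit of > 50000 nM in this assay, at which 1 of the 3 values shown sits. Compound 1 and compound 2 stand at the limit of > 10000 nM in this assay, at which 2 of the 3 values shown sit. Going by the values given here, no toxicity order can be read from these limits, and no measured pair here differs in a single place.

Compound 4 `CNC(=O)[C@@H](NC(=O)[C@@](O)(CCCN(Cc1ccc(C#Cc2ccncc2)cc1)NC(=O)[C@@H](NC(=O)OC)C(C)(C)C)Cc1ccccc1)C(C)(C)C` is the next structure to be tested in this assay. It carries 2-(pyridin-4-yl)ethynyl in place of pyridin-4-yl on an aromatic carbon of a six-membered aromatic ring of carbon only, para to a large group: 2-(pyridin-4-yl)ethynyl in place of pyridin-4-yl on an aromatic carbon. The entering group adds a triple bond outside aromatic rings and keeps the pyridine ring.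

The expectation rests mainly on compound 3, whose > 50000 nM is a limit. No step beyond the usual scatter is expected, and a further limit is the likeliest report. The estimated step is a number no higher from compound 3 to compound 4 (the limit leaves the size open). For compound 4 the estimated half-maximal cytotoxic concentration is 50000 nM, with an expected range of 20000 nM to 100000 nM.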

Compound 4, half-maximal cytotoxic concentration: > 50000 nM
Compound 4 was reported as a limit (the forecaster's own chance of this, stated with the estimate: 85%); the middle value sits exactly at the limit.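

In this assay compound 4 gives > 50000 nM, which is a limit of the assay. Compound 3 gives > 50000 nM, also a limit. No step can be read from compound 3 to compound 4. The compounds shown leave open how 2-(pyridin-4-yl)ethynyl in place of pyridin-4-yl bears on the half-maximal cytotoxic concentration.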